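The source may hold more compounds than are shown below. What is called first, only, known or untested is meant among the compounds shown, and "the series" means these compounds.

Measured compounds in a functional assay on A875 cells (Homo sapiens) for antiproliferative activity, read by MTT assay, with a stated time of 48 h; on this read-out higher numbers stand for weaker inhibition and lower numbers for stronger inhibition:
compound 1, `O=C(CCCl)Nc1ccc(SCC(=O)Nc2cc(Cl)ccn2)cc1`, gives 12300 nM
compound 2, `O=C(CCCl)Nc1ccc(SCC(=O)Nc2ccccn2)cc1`, gives 29500 nM
compound 3, `C=CC(=O)Nc1ccc(SCC(=O)Nc2cc(Cl)ccn2)cc1`, gives 14700 nM

Compound 4, `C=CC(=O)Nc1ccc(SCC(=O)Nc2ccccn2)cc1`, has not been measured.

Within the measured set, one change is seen twice in structure. The first instance runs from compound 1 to compound 2: hydrogen in place of chloro on an aromatic carbon. Its measured effect is a 2.4-fold higher number from compound 1 to compound 2 (0.38 log units; beyond the scatter). The second instance runs from compound 3 to compound 4: hydrogen in place of chloro on an aromatic carbon. The place of the change is described in the same words for both pairs, so the two instances count as the same change.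

The two cores on which this change is made are not identical. Compound 3 differs from compound 1 in one respect: vinyl in place of 2-chloroethyl on a carbonyl carbon. That difference gave a 1.2-fold higher number from compound 1 to compound 3 (0.08 log units; within the scatter), so the two cores sit close together on this read-out, and compound 3 is, on the measured numbers, not separated from compound 1.

For compound 4, the expectation rests on transferring the step seen from compound 1 to compound 2 onto compound 3. Because the core difference, a 1.2-fold higher number from compound 1 to compound 3 (0.08 log units; within the scatter), lies within the scatter, there is no reason from the data to expect the second instance to behave differently from the first. The expected step is a 2.3-fold higher number from compound 3 to compound 4 (0.36 log units; beyond the scatter), beside the earlier step of a 2.4-fold higher number from compound 1 to compound 2 (0.38 log units; beyond the scatter).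

Compound 4 is accordingly estimated at 34000 nM in this assay, with an expected range from 15000 nM to 75000 nM.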

Compound 4, half-maximal inhibitory concentration: 23400 nM
The estimate for compound 4 lay 1.5-fold (0.16 log units) above the measured number; the range from low to high includes it.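

In this assay, hydrogen in place of chloro on the aromatic carbon, 4-chloropyridin-2-yl to pyridin-2-yl, gives a 1.6-fold higher number from compound 3 to compound 4 (0.20 log units; within the scatter), and this step does not separate from its earlier instance: the same change on two cores in this assay, a 2.4-fold higher number (0.38 log units; beyond the scatter) from compound 1 to compound 2 and a 1.6-fold higher number (0.20 log units; within the scatter) from compound 3 to compound 4, 1.5-fold (0.18 log units) apart, within the scatter of two such steps

Vinyl in place of 2-chloroethyl on the carbonyl carbon, read on the pyridin-2-yl pair, gives a 1.3-fold lower number from compound 2 to compound 4 (0.10 log units; within the scatter), and it likewise agrees with its earlier instance: the same change on two cores in this assay, a 1.2-fold higher number (0.08 log units; within the scatter) from compound 1 to compound 3 and a 1.3-fold lower number (0.10 log units; within the scatter) from compound 2 to compound 4, 1.5-fold (0.18 log units) apart, within the scatter of two such steps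

Across these four compounds, each change therefore carries from one core to the other without a measurable difference, but this does not confirm a chloro effect on the core of compound 3, since the step on that core lies within the scatter whereas the step from compound 1 to compound 2 lies beyond it; a single pair of cores also cannot show that the agreement holds more widely in the series.

The compounds shown leave open what other groups would do at the place of the chloro, for example a fluoro group, a methoxy group or an amine. They also leave open whether a longer chain on the carbonyl carbon would behave like vinyl and 2-chloroethyl, which remain unseparated on both cores.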